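Dichlorophenyl in place of methylphenyl on the lactone series

A few compounds are considered here, and "the series" means these few. Any claim that something is new, unique, unknown or untested is made for them only; others in the source may bear on it.

Compound 1 `Cc1cccc(-c2cc(Cl)cc(Cl)c2/C=C/[C@@H]2C[C@@H](O)CC(=O)O2)c1` in an assay for inhibition of 3-hydroxy-3-methylglutaryl-coenzyme A reductase (Rattus norvegicus) (on this read-out higher numbers stand for weaker inhibition and lower numbers for stronger inhibition), gives 16 nM. Compound 2 `Cc1cc(-c2cccc(Cl)c2/C=C/[C@@H]2C[C@@H](O)CC(=O)O2)ccc1F` in this assay gives 30 nM; its number and that of compound 1 lie within the usual scatter of each other, so no order between the two is claimed. Compound 3 `O=C1C[C@H](O)C[C@@H](/C=C/c2c(Cl)cc(Cl)cc2-c2ccc(Cl)c(Cl)c2)O1` is not yet measured. It differs from compound 1 by 3,4-dichlorophenyl in place of 3-methylphenyl on an aromatic carbon. Within the data shown here, no measured step between two compounds shows what such a change does here, so the expectation rests on compound 1 alone. A step of a 1.3-fold higher number from compound 1 to compound 3 (0.10 log units; within the scatter) is expected, none beyond the scatter in either direction. Compound 3 is estimated at 20 nM, with a range from 8 nM to 50 nM.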

Compound 3, half-maximal inhibitory concentration: 25 nM
The estimate for compound 3 lay 1.3-fold (0.10 log units) below the measured number, and the stated range covers the measured number.
By their numbers in this assay, from the lowest: compounds 1, 3 and 2 (each within the scatter of the next).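

In this assay, 3,4-dichlorophenyl in place of 3-methylphenyl on this aromatic carbon gives a 1.6-fold higher number from compound 1 to compound 3 (0.19 log units; within the scatter). Among these compounds, this is the first step read at this position, and it shows that the position accepts this exchange of substituted phenyl groups with no change beyond the scatter. No measured evidence bearing on this result is available.

Open, from the compounds shown here alone, is whether a phenyl carrying an amine or a carboxylic acid on this aromatic carbon would also stay within the scatter of compound 1. A single step also cannot separate the contributions of the two chlorines.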